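From 2-chlorobenzyl to 2-bromobenzyl

A few compounds are considered here, and "the series" means these few. Any claim that something is new, unique, unknown or untested is made for them only; others in the source may bear on it.

In a functional assay on U-251 cells (Homo sapiens) for antiproliferative activity, read by MTT assay, with a stated time of 24 h (on this read-out lower numbers stand for stronger inhibition and higher numbers for weaker inhibition), compound 1 `COc1cc(OC)c(-c2coc3cc(OCc4ccccc4C)ccc3c2=O)cc1OC` gives 2000 nM. Compound 2 `COc1cc(OC)c(-c2coc3cc(OCc4ccccc4Cl)ccc3c2=O)cc1OC` carries chloro in place of the methyl of compound 1. In this assay, compound 2 gives only a limit, > 10000 nM, and not a number. Among the compounds with values here, the single measured step is an at least 5.0-fold higher number from compound 1 to compound 2 (0.69 log units; beyond the scatter), and its size is known only as a bound.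

Compound 3 `COc1cc(OC)c(-c2coc3cc(OCc4ccccc4Br)ccc3c2=O)cc1OC` has not yet been measured. It has bromo in place of chloro on an aromatic carbon, ortho to a large group: bromo in place of chloro on an aromatic carbon. The measured step bears on this change only indirectly, since it replaced methyl rather than chloro. It does show that a substitution at this place can move the read-out beyond the scatter. Within the data shown here, no measured step starts from chloro, so the direction of the new step remains open, and only a modest step in either direction is expected. Compound 3 is therefore expected to remain on the weak side, near the limit reached by compound 2, and it may also return only a limit. The expected step is a number no higher from compound 2 to compound 3 (the limit leaves the size open). For compound 3 the estimate is 10000 nM, within an expected range of 3000 nM to 30000 nM.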

Compound 3, half-maximal inhibitory concentration: > 10000 nM
Compound 3 gave a limit, no number; the forecaster's own chance of this, stated with the estimate: 55%; the middle value lies on the limit itself.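

Bromo in place of methyl gives an at least 5.0-fold higher number from compound 1 to compound 3 (0.69 log units; beyond the scatter), so the loss seen with chloro is not confined to that one atom: a second halogen at this place also moves the read-out beyond the scatter. Among the three compounds shown, only the methyl of compound 1 yields a number in this assay, and both halogens end at a limit. The change from chloro to bromo itself cannot be read, and the read-out is what stops it: the limit of > 10000 nM in this assay, at which 2 of the 3 values shown sit.

Going by these compounds, how far compound 2 and compound 3 actually lie from each other therefore stays unknown, and they may differ or may not. Also open, on these data alone, is whether fluoro, methoxy or an ethyl group at this place would give a number, as methyl does, or end at the limit as chloro and bromo do.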